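From Chlorine to Methyl on the Pyridine Arm

A few compounds are considered here, and "the series" means these few. Any claim that something is new, unique, unknown or untested is made for them only; others in the source may bear on it.

Two measured compounds set the stage. Compound 1 `C[C@@H](Oc1cc2onc(CCC(=O)O)c2cc1Cl)c1ccc(Cl)cn1` was tested in an assay for inhibition of kynurenine 3-monooxygenase (Homo sapiens), read by mass spectrometry, with a stated time of 1 h (on this read-out lower numbers stand for stronger inhibition and higher numbers for weaker inhibition), where compound 1 gives 3.16 nM. Compound 2 `C[C@@H](Oc1cc2oc(=O)n(CCC(=O)O)c2cc1Cl)c1ccc(Cl)cn1`, which carries a different shared core but the same pyridine arm, was tested in this assay too, and compound 2 gives 3.16 nM. On the digits shown, compound 2 stands level with compound 1, and the two values lie within the scatter of each other, so neither can be called more or less potent than the other.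

Compound 3 `Cc1ccnc([C@@H](C)Oc2cc3oc(=O)n(CCC(=O)O)c3cc2Cl)c1` has not been measured in this assay. It differs from compound 2 in one place: 4-methylpyridin-2-yl in place of 5-chloropyridin-2-yl on a saturated chain carbon bound to an oxygen on an aromatic ring and a saturated chain carbon. Within the data shown here, nothing among the measured pairs tracks this kind of change, so the expectation rests only on the pyridine arm being kept intact apart from its substituent. The step of a 1.6-fold higher number from compound 2 to compound 3 (0.20 log units; within the scatter) is expected to be small, leaning toward weaker inhibition, but not clearly beyond the scatter. Compound 3 is therefore estimated at 5 nM, with a range from 1.5 nM to 16 nM.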

Compound 3, half-maximal inhibitory concentration: 3.98 nM
The estimate for compound 3 lay 1.3-fold (0.10 log units) above the measured number; the range from low to high includes it.
By their numbers in this assay, from the lowest: compounds 1, 2 and 3 (each within the scatter of the next).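

In this assay, putting 4-methylpyridin-2-yl in place of 5-chloropyridin-2-yl on the saturated chain carbon gives a small step (a 1.3-fold higher number from compound 2 to compound 3 (0.10 log units; within the scatter)), so this pair shows that a pyridine arm without chlorine can hold a value within the scatter of the chlorinated one. Among these compounds, compound 1 and compound 2 carry the same 5-chloropyridin-2-yl arm and differ only in the core, so they could say nothing about this position, and this is the first view of the arm being changed. No measurement shown here accounts for how small the step is.

The single pair changes both the group and its place on the pyridine ring, so it cannot separate the loss of the chlorine from the arrival of the methyl, and 5-methylpyridin-2-yl, 4-chloropyridin-2-yl and the bare pyridin-2-yl, which would pull these apart, are not among the compounds shown. On these data alone, it also remains open whether a larger group on this ring, such as methoxy or a nitrile, would stay within the scatter, and whether 4-methylpyridin-2-yl would behave the same way on the core of compound 1.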